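The compounds below may be only part of what the source reports. "The series", "measured", "known", "first", "only" and "open" are said of these compounds alone.

Compound 1 `Cc1cc(-c2ccc3[nH]c(=O)nc(-c4ccccc4)c3c2)ccn1` was examined in an ADME assay on THP-1 cells (Homo sapiens) for cytotoxicity, read by MTT assay, with a stated time of 72 h; on this read-out higher numbers stand for an effect only at larger amounts of compound and lower numbers for an effect already at smaller amounts. In this assay compound 1 gives > 50000 nM, which is a limit of the assay rather than a number. Compound 2 `O=c1nc(-c2ccccc2)c2cc(-c3cccnc3)ccc2[nH]1` likewise reaches only a limit in this assay, namely > 50000 nM. Compound 3 `O=c1nc(-c2ccccc2)c2cc(-c3cncnc3)ccc2[nH]1` also gives a limit in this assay, > 50000 nM. The steps a step that the two limits leave unreadable from compound 1 to compound 2, a step that the two limits leave unreadable from compound 1 to compound 3 and a step that the two limits leave unreadable from compound 2 to compound 3 cannot be given a size because of the limit of > 50000 nM in this assay, at which 3 of the 3 values shown sit. Compound 4 `O=c1nc(-c2ccccc2)c2cc(-c3cc[nH]n3)ccc2[nH]1` differs from compound 1 as follows: 1H-pyrazol-3-yl in place of 2-methylpyridin-4-yl on an aromatic carbon. Among the compounds with values here, none of the measured steps has a readable size, so no step beyond the scatter is expected from this change. Compound 4 is therefore expected to give 60000 nM in this assay, within a range from 30000 nM to 150000 nM. The step expected is a step that the limit leaves unreadable from compound 1 to compound 4.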

Compound 4, half-maximal effective concentration: > 50000 nM
Compound 4 gave a limit, no number (the forecaster's own chance of this, stated with the estimate: 85%); the middle value does not contradict the limit.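

Compound 4 gives > 50000 nM in this assay, which is a limit, so its steps from compound 1, compound 2 and compound 3 cannot be read. The compounds shown leave open what amount of any of these four would produce an effect in this assay, and whether they differ at all.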